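Swapping cyano for hydroxymethyl in a weak series

The source may report more compounds than this note shows. Statements on the series, on what has been measured and on what is new or still open speak of the compounds shown alone.

In a functional assay on HeLa cells (Homo sapiens) for inhibition (a lower number here means a stronger inhibitor, a higher number a weaker inhibitor), compound 1 `Nc1ccn(/C=C/C=O)c(=O)n1` gives > 100000 nM, which is a limit and not a number. Compound 2 `Cc1cn(/C=C/C#N)c(=O)[nH]c1=O` gives > 100000 nM, also a limit. Compound 2 therefore has no exact value and stands with compound 1 at the same limit: the limit of > 100000 nM in this assay, at which 2 of the 2 values shown sit. For the measured compounds named here, no measured step connects the two compounds, so the series offers no size of effect to carry forward.

Compound 3 `Cc1cn(/C=C/CO)c(=O)[nH]c1=O` carries hydroxymethyl in place of cyano on a double-bonded chain carbon bound to a double-bonded chain carbon. In this assay, no step beyond the usual scatter is expected, and neither direction is favoured. The expected change is a step that the limit leaves unreadable from compound 2 to compound 3. A further limit is the likeliest report. For compound 3 the estimated value is 120000 nM, with an expected range from 40000 nM to 300000 nM.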

Compound 3, half-maximal inhibitory concentration: > 100000 nM
Compound 3 was reported as a limit (the forecaster's own chance of this, stated with the estimate: 85%); the middle value lies beyond the limit too.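

In this assay compound 3 gives > 100000 nM as a limit and not a number. For the compounds shown here, compound 2 also stands at a limit, so no step between compound 2 and compound 3 can be read: the limit of > 100000 nM in this assay, at which 3 of the 3 values shown sit. The compounds shown leave open whether hydroxymethyl in place of cyano changes inhibition at all.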